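The source may hold more compounds than are shown below. What is called first, only, known or untested is meant among the compounds shown, and "the series" means these compounds.

In a functional assay on B16-F10 cells (Mus musculus) (a lower number here means that less compound is needed, a higher number that more compound is needed for the effect), compound 2 `Nc1ncn(C[C@H]2CO[C@H](CO)O2)c(=O)n1` gives 70000 nM, and compound 1 `Nc1ncn(C[C@@H]2CO[C@H](CO)O2)c(=O)n1` gives 70000 nM, so the two stand level at these digits. Compound 3 `Cc1nn(C[C@H]2CO[C@H](CO)O2)c(=O)[nH]c1=O` reaches only a limit of the assay, > 100000 nM. Compound 4 `Nc1ncn(C[C@H]2CO[C@@H](CO)O2)c(=O)n1` comes from compound 2 through one change: the two compounds have the same atoms and bonds and differ only in configuration as drawn: 1 of 2 stereo elements differ; a stereocentre at a saturated ring carbon is drawn S in compound 2 and R in compound 4. For the measured compounds named here, only one measured step bears on this, no change at the digits printed from compound 1 to compound 2 (within the scatter), which also altered a single stereocentre at a saturated ring carbon and stayed within the scatter (the fact that compounds 1 and 2 differ only in the configuration as drawn). One step is thin evidence, but it points to no clear shift in this assay in either direction. The expected result is no change at the digits printed from compound 2 to compound 4 (within the scatter), which means no shift beyond the scatter. For compound 4 the estimated value is 70000 nM, with an expected range from 25000 nM to 120000 nM.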

Compound 4, half-maximal effective concentration: 60000 nM
Compound 4: the middle estimate sits 1.2-fold (0.07 log units) above what was measured; the range from low to high includes it.
By their numbers in this assay, from the lowest: compounds 4, 1 and 2 (each within the scatter of the next). At a limit, above all of these: compound 3.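

In this assay, inverting the other stereocentre at a saturated ring carbon gives a 1.2-fold lower number from compound 2 to compound 4 (0.07 log units; within the scatter), so this centre, like the one changed earlier, shows no effect of configuration beyond the scatter. The new mirror-image pair adds a 1.2-fold lower number from compound 1 to compound 4 (0.07 log units; within the scatter), so inverting both centres together also stays within the scatter. Among compounds 1, 2 and 4, configuration at these two ring carbons therefore makes no visible difference.

From the compounds shown here alone, the mirror image of compound 2 remains open. So does whether an amine or a carboxylic acid in place of the hydroxymethyl group would shift the number.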